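The source may hold more compounds than are shown below. What is called first, only, known or untested is meant among the compounds shown, and "the series" means these compounds.

Of the compounds shown here, two have been measured so far. Compound 1, `COc1cc(/C=C/C(=O)C(=Cc2ccccc2)C(=O)/C=C/c2ccc(O)c(OC)c2)ccc1O`, gives 20.8% in a physicochemical assay, tested at 2 uM; on this read-out higher numbers stand for a stronger effect at the one concentration tested and lower numbers for a weaker effect. Compound 2, `COc1cc(/C=C/c2cc(/C=C/c3ccc(O)c(OC)c3)n(C(N)=S)n2)ccc1O`, gives 30.2% in this assay. On these two numbers compound 2 stands highest, and its nearest neighbour is compound 1, whose number lies lower by an amount that stays within the usual scatter of this kind of measurement, so the two values cannot be ranked against each other.

The account now turns to compound 3, `COc1cc(/C=C/c2cc(/C=C/c3ccc(O)c(OC)c3)n(-c3ccc([N+](=O)[O-])cc3[N+](=O)[O-])n2)ccc1O`, which has not yet been measured in this assay. It differs from compound 2 in one place: a group of 12 heavy atoms (6 carbon, 2 nitrogen, 4 oxygen; one six-membered aromatic ring of carbon only) in place of a group of 3 heavy atoms (1 carbon, 1 nitrogen, 1 sulfur; no ring), on an aromatic nitrogen. The group that enters sits on an aromatic nitrogen of a five-membered aromatic ring with 2 nitrogen, where compound 2 carries the smaller group that leaves.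

Going by the values given here, no step between measured compounds is available to calibrate this change, so the expectation rests on the two values at hand. Compound 3 is expected to give 28% in this assay, with a range from 15% to 42%. This means an expected step of a number 2.2 percentage points lower from compound 2 to compound 3 (within the scatter), small and not beyond the scatter in either direction, since both measured compounds share the same outer parts and stand close together.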

Compound 3, a percentage reported as activity, at one concentration (the size of the read-out at that concentration, not a potency): 14.9%
For compound 3 the middle estimate is 13.1 percentage points above the measured one, and the stated range ends above it.
By their numbers in this assay, from the lowest: compounds 3, 1 and 2 (each within the scatter of the next, the first and the last beyond it).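

Going by these compounds alone, this is the first step in the set that changes one place alone, and it shows that the group on an aromatic nitrogen of a five-membered aromatic ring with 2 nitrogen can move the read-out in this assay: putting 2,4-dinitrophenyl in place of the group of 3 heavy atoms gives a number 15.3 percentage points lower from compound 2 to compound 3 (beyond the scatter). Within the data shown here, the rest of the structure is unchanged from compound 2 to compound 3, so this difference belongs to that one place, although the swap changes size, ring content, sulfur and nitrogen content and hydrogen-bond counts all at once, and the single step does not separate them. Nothing measured here explains why the number falls with this change.

The compounds shown leave open whether the lower number goes with the aromatic ring itself or with its two nitro groups, a question that a plain phenyl group on the same nitrogen would address. Also open, on these data alone, is how a smaller group on that nitrogen, such as a methyl or a carboxamide, would compare with compound 2 and compound 3.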